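A few compounds are considered here, and "the series" means these few. Any claim that something is new, unique, unknown or untested is made for them only; others in the source may bear on it.

Measured compounds in an ADME assay on HepG2 cells (Homo sapiens) for cytotoxicity, read by sulforhodamine B assay, with a stated time of 48 h; on this read-out higher numbers stand for lower toxicity in this test and lower numbers for higher toxicity in this test:

- compound 1 `COc1nc2ccccc2cc1/C=C/c1noc(-c2ccccc2)n1`: reported only as a limit, > 240000 nM
- compound 2 `COc1nc2ccccc2cc1/C=C/c1noc(-c2ccc(C)cc2)n1`: reported only as a limit, > 230000 nM
- compound 3 `COc1ccc(-c2nc(/C=C/c3cc4ccccc4nc3OC)no2)cc1`: reported only as a limit, > 220000 nM

Compound 1 stands at a limit of this assay, not at a number; the same holds for the two compounds measured beside it, so no order among the three can be read. The steps a step that the two limits leave unreadable from compound 1 to compound 2 and a step that the two limits leave unreadable from compound 1 to compound 3 are both left unreadable by the two limits, as is a step that the two limits leave unreadable from compound 2 to compound 3; the limits themselves are summarised in the limit of > 240000 nM in this assay, at which 1 of the 3 values shown sits, the limit of > 230000 nM in this assay, at which 1 of the 3 values shown sits, and (the limit of > 220000 nM in this assay, at which 1 of the 3 values shown sits).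

Compound 4 `COc1ccccc1-c1nc(/C=C/c2cc3ccccc3nc2OC)no1` is not yet measured. It differs from compound 1 by methoxy in place of hydrogen on an aromatic carbon, the entering group sitting on an aromatic carbon of a six-membered aromatic ring of carbon only, ortho to a large group. Among the measured compounds shown here, the only comparable change, methoxy in place of hydrogen on an aromatic carbon, was the step from compound 1 to compound 3, which stayed unreadable between two limits. For the measured compounds named here, no measured step therefore gives a direction, and none beyond the scatter is expected; compound 4 is most likely to be reported as a limit again.

Estimated for compound 4 in this assay: 240000 nM, range 120000 nM to 500000 nM, which would mean a step of a number no higher from compound 1 to compound 4 (the limit leaves the size open) within the scatter.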

Compound 4, half-maximal cytotoxic concentration: > 220000 nM
Compound 4: only a limit was reported; the forecaster's own chance of this, stated with the estimate: 85%; the middle value does not contradict the limit.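

In this assay compound 4 gives > 220000 nM, which is a limit. Its steps to compound 1, compound 2 and compound 3 cannot be read. The compounds shown leave open what half-maximal cytotoxic concentration any of the four would actually reach, and whether the substituents differ at all.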